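The source may hold more compounds than are shown below. What is called first, only, known or untested is meant among the compounds shown, and "the series" means these compounds.

In a functional assay on NCI-H460 cells (Homo sapiens) for antiproliferative activity, read by CCK-8 assay, with a stated time of 72 h (on this read-out higher numbers stand for weaker inhibition and lower numbers for stronger inhibition), compound 1 `Cc1ccc(Nc2nc(Cl)nc3c2ncn3Cc2ccc(C(=O)Nc3ccccc3N)cc2)cc1` gives 1590 nM and compound 2 `Nc1ccccc1NC(=O)c1ccc(Cn2cnc3c(Nc4cccc(Cl)c4)nc(Cl)nc32)cc1` gives 6580 nM, the higher of the two numbers. Compound 3 `CN1CCN(c2nc(Cl)nc3c2ncn3Cc2ccc(C(=O)Nc3ccccc3N)cc2)CC1` departs from compound 2 at one place: 4-methylpiperazin-1-yl in place of (3-chlorophenyl)amino on an aromatic carbon. For the measured compounds named here, the only measured step, a 4.1-fold higher number from compound 1 to compound 2 (0.62 log units; beyond the scatter), exchanges one substituted phenyl group for another, so it bears only loosely on this replacement. Going by the values given here, with compound 1 at 1590 nM as the sole lower value, a modest move towards a lower number is expected. The expected change is a 2.2-fold lower number from compound 2 to compound 3 (0.34 log units; beyond the scatter). Compound 3 is estimated at 3000 nM, with an expected range from 700 nM to 12000 nM.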

Compound 3, half-maximal inhibitory concentration: 6160 nM
Beside the measured number, compound 3's estimate is 2.1-fold (0.31 log units) below it; the range from low to high includes it.
By their numbers in this assay, from the lowest: compound 1; then compounds 3 and 2 (each within the scatter of the next).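

In this assay, the step from the aryl amino group to a non-aromatic ring with no hydrogen-bond donor gives a 1.1-fold lower number from compound 2 to compound 3 (0.03 log units; within the scatter), so at this position the 3-chlorophenyl ring and its donor can be exchanged for 4-methylpiperazin-1-yl without a change beyond the scatter. The same group set against (4-methylphenyl)amino gives a 3.9-fold higher number from compound 1 to compound 3 (0.59 log units; beyond the scatter), so it does not reach the level of compound 1. Nothing available accounts for either step. As far as these compounds go, it remains open whether a morpholine, a piperazine without the methyl group or a simple alkylamine at this carbon would match compound 1 or go past it.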